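A few compounds are considered here, and "the series" means these few. Any claim that something is new, unique, unknown or untested is made for them only; others in the source may bear on it.

Measured compounds:
- compound 1, `CSc1nc(NCCCCCO)c2ccccc2n1`, 39300 nM
- compound 2, `[SeH]c1nc(NCc2ccccc2)c2cccnc2n1`, 8400 nM
- compound 3, `CSc1nc(NCCCc2ccccc2)c2ccccc2n1`, 73400 nM

These three were tested in an ADME assay on BEAS-2B cells (Homo sapiens) for cytotoxicity, read by MTT assay, with a stated time of 72 h; on this read-out lower numbers stand for stronger inhibition of growth and higher numbers for weaker inhibition of growth. Compound 1 stands second highest of the three numbers: its nearest neighbour is compound 3, reached by a 1.9-fold higher number from compound 1 to compound 3 (0.27 log units; within the scatter); compound 2 lies furthest away, with a lower number that sits beyond the usual scatter.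

Compound 4, `CSc1nc(Nc2ccccc2)c2ccccc2n1`, has not yet been measured. It differs from compound 1 in one place: phenyl in place of 5-hydroxypentyl on a nitrogen on an aromatic ring. The nearest measured comparison is the step from compound 1 to compound 3, where a phenyl took the place of a 2-hydroxyethyl on a saturated chain carbon; that step gave a 1.9-fold higher number from compound 1 to compound 3 (0.27 log units; within the scatter), a change that stays within the scatter. Among the compounds with values here, the change to compound 4 is not the same, since the phenyl now sits directly on the ring nitrogen and the whole 5-hydroxypentyl chain leaves, but the only measured swap of a hydroxyl-bearing chain for a phenyl moved the number very little. On that basis the step of a 1.1-fold higher number from compound 1 to compound 4 (0.06 log units; within the scatter) is expected to be small, with no clear direction beyond the scatter. Compound 4 is therefore estimated at 45000 nM, with a likely range from 13000 nM to 150000 nM.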

Compound 4, concentration for 50% growth inhibition: 54800 nM
For compound 4 the middle estimate is 1.2-fold (0.09 log units) below the measured one; low and high end bracket the measured number.
By their numbers in this assay, from the lowest: compound 2; then compounds 1, 4 and 3 (each within the scatter of the next).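

In this assay, putting phenyl in place of 5-hydroxypentyl on a nitrogen on an aromatic ring gives a 1.4-fold higher number from compound 1 to compound 4 (0.14 log units; within the scatter), so this swap leaves the number within the usual scatter. The earlier step from compound 1 to compound 3 left part of the chain on this nitrogen, whereas here the whole 5-hydroxypentyl chain leaves, along with its hydrogen-bond donor and acceptor, and an aromatic ring of carbon only sits directly on the nitrogen. Even this larger change in the kind of group does not move the number beyond the scatter, but no separate measurement bears on this result, so the data offer no explanation for it.

Still open, as far as these compounds go, is whether a group of another kind on this nitrogen, such as an amine, a carboxylic acid or a phenyl ring carrying a chlorine, would shift the number beyond the scatter. Within the data shown here, compound 2 is the only compound with a number beyond the scatter of compound 1, but it differs from the others in more than one place, so its lower number cannot be tied to any single change.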